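Swapping a hydroxypentyl chain for cyclopentyl

The compounds below may be only part of what the source reports. "The series", "measured", "known", "first", "only" and "open" are said of these compounds alone.

compound 1 `O=S(=O)(/C=C/c1ccc(O)c(O)c1)CCC1CCCCC1`: 9800 nM
compound 2 `O=S(=O)(/C=C/c1ccc(O)c(O)c1)CCCCCCCO`: 5900 nM

For the measured compounds named here, in a functional assay, read by fluorescence and spectrophotometry, with a stated time of 1 h (on this read-out lower numbers stand for an effect already at smaller amounts and higher numbers for an effect only at larger amounts of compound), compound 2 has only one measured neighbour and stands level with it, within the scatter. Compound 3 `O=S(=O)(/C=C/c1ccc(O)c(O)c1)CCC1CCCC1` brings a new change: cyclopentyl in place of 5-hydroxypentyl on a saturated chain carbon, two bonds along the chain from a sulfonyl sulfur. Going by the values given here, the only measured step that bears on this is a 1.7-fold lower number from compound 1 to compound 2 (0.22 log units; within the scatter) and it exchanged cyclohexyl for the same 5-hydroxypentyl group. Among the compounds with values here, with one small step as the only guide, no change beyond the scatter is expected. The expected step in this assay is a 1.5-fold higher number from compound 2 to compound 3 (0.18 log units; within the scatter). Compound 3 is estimated at 9000 nM with an expected range of 4000 nM to 20000 nM.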

Compound 3, half-maximal effective concentration: 6800 nM
Compound 3: the middle estimate sits 1.3-fold (0.12 log units) above what was measured; measured number inside the range.
By their numbers in this assay, from the lowest: compounds 2, 3 and 1 (each within the scatter of the next).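

In this assay, cyclopentyl in place of 5-hydroxypentyl gives a 1.2-fold higher number from compound 2 to compound 3 (0.06 log units; within the scatter), and cyclopentyl in place of cyclohexyl gives a 1.4-fold lower number from compound 1 to compound 3 (0.16 log units; within the scatter). On this saturated chain carbon, two bonds along the chain from a sulfonyl sulfur, cyclopentyl, cyclohexyl and the 5-hydroxypentyl chain therefore all stand level, so neither ring size nor the swap from ring to open chain shows an effect beyond the scatter. Nothing available explains why these groups read alike. Going by these compounds, whether an amine or a carboxylic acid at this place would move the number beyond the scatter stays open.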